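The source may report more compounds than this note shows. Statements on the series, on what has been measured and on what is new or still open speak of the compounds shown alone.

Series of two measured compounds and one pending. In an assay on isolated protein for inhibition of DNA topoisomerase 1 (Homo sapiens), with a stated time of 30 min, tested at 100 uM (on this read-out lower numbers stand for a weaker effect and higher numbers for a stronger effect at the one concentration tested), compound 1 `Cc1cccc(-c2nc3ccc(C)cc3c(=O)[nH]2)c1` gives 75.7%, and compound 2 `Cc1ccc2nc(-c3cccc(F)c3)[nH]c(=O)c2c1` gives 82.9%. Going by the values given here, of the two numbers, compound 2 carries the higher, but the single measured step, a number 7.2 percentage points higher from compound 1 to compound 2 (within the scatter), lies within the scatter, so the two cannot be told apart.

Compound 3 `Cc1ccc2nc(-c3cccc(OC(F)(F)F)c3)[nH]c(=O)c2c1` differs from compound 2 by trifluoromethoxy in place of fluoro on an aromatic carbon. Among the compounds with values here, no measured step bears on this change directly: the only step recorded concerns fluoro in place of methyl at the same aromatic carbon and stays within the scatter. Within the data shown here, with no step leaving the scatter, the expectation for compound 3 is a number near that of compound 2, with a step of a number 4.9 percentage points lower from compound 2 to compound 3 (within the scatter) that is expected to stay within the usual spread. Compound 3 is therefore estimated at 78% in this assay, with a range from 60% to 92%.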

Compound 3, a percentage reported as inhibition, at one concentration (the size of the read-out at that concentration, not a potency): 98.6%
Beside the measured number, compound 3's estimate is 20.6 percentage points below it, outside the stated range (above it).
By their numbers in this assay, from the lowest: compounds 1 and 2 (each within the scatter of the next); then compound 3.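

In this assay, the aromatic carbon meta to a large group now shows a change beyond the scatter: trifluoromethoxy in place of fluoro gives a number 15.7 percentage points higher from compound 2 to compound 3 (beyond the scatter), and trifluoromethoxy in place of methyl gives a number 22.9 percentage points higher from compound 1 to compound 3 (beyond the scatter). Compound 3 therefore stands above both other compounds, so this position is not indifferent to its substituent, which the comparison of methyl and fluoro alone could not show. No data given here account for the higher number.

Going by these compounds, it remains open whether trifluoromethoxy is particular in this respect, or whether trifluoromethyl, methoxy or a longer chain such as ethoxy on the same carbon would read alike. On these data alone, how an amine or a carboxylic acid would read at this position also remains open, as does whether the same change would carry over to another carbon of this ring.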